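This account rests on a few compounds, and the source may have more. Where it says the series, first, only, none or still open, it means among the compounds named here.

Compound 1 `Cc1cccc(-c2cnc(N)nc2-c2ccccc2)c1` in an assay on CHO cells for displacement of a labelled ligand from adenosine receptor A1 (Homo sapiens), read by scintillation counting, with a stated time of 1 h, tested at 1 uM (on this read-out lower numbers stand for less inhibition and higher numbers for more inhibition at the one concentration tested (going by the name of the read-out)), gives > 80%, a limit of the assay rather than a number. Compound 2 `Cc1ccc(-c2cnc(N)nc2-c2ccccc2)cc1` gives 51%. Compound 3 `Nc1ncc(-c2ccc(F)cc2)c(-c2ccccc2)n1` gives > 80%, again a limit.

Compound 1 thus sits at the limit of > 80% in this assay, at which 2 of the 3 values shown sit, so only a limit is known for it. Compound 4 `Nc1ncc(-c2cccc(Cl)c2)c(-c2ccccc2)n1` is not yet measured; it differs from compound 1 by chloro in place of methyl on an aromatic carbon. Among the measured compounds shown here, the one measured step of a similar kind is a number at least 29 percentage points higher from compound 2 to compound 3 (beyond the scatter), at least modest and upward. Since compound 1 is already at the limit, the expected step that the limit leaves unreadable from compound 1 to compound 4 is none beyond the scatter. Compound 4 is therefore estimated at 85%, between 70% and 95%.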

Compound 4, a percentage reported as inhibition, at one concentration (the size of the read-out at that concentration, not a potency): > 80%
Compound 4: only a limit was reported; the forecaster's own chance of this, stated with the estimate: 70%; the middle value lies beyond the limit too.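

No step can be read from compound 1 to compound 4, since both give a limit of the assay rather than a number: the limit of > 80% in this assay, at which 3 of the 4 values shown sit. The compounds shown leave open whether chloro or methyl at this place gives more inhibition.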